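Amide to methyl ester on two dimethyltriazene cores

The compounds below may be only part of what the source reports. "The series", "measured", "known", "first", "only" and "open" are said of these compounds alone.

Compound 1 `CN(C)/N=N/c1cccc(C(N)=O)c1` carries a carbamoyl group, and in a functional assay on L1210 cells (Mus musculus) for antiproliferative activity (on this read-out lower numbers stand for lower potency and higher numbers for higher potency (the scale is a negative logarithm)), compound 1 gives 3.8. Compound 2 `COC(=O)c1cccc(/N=N/N(C)C)c1` differs from compound 1 in one place: methoxy in place of amino on a carbonyl carbon. In this assay compound 2 gives 3.42; the step is a number 0.38 log units lower from compound 1 to compound 2 (beyond the scatter). Among the compounds with values here, this is the only measured instance of that change among the compounds here.

Compound 3 `CN(C)/N=N/c1n[nH]cc1C(N)=O` sits on a different core; the difference between the two cores is not broken down here. In this assay compound 3 gives 3.49, a number within the scatter of compound 2 and lower than that of compound 1.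

Compound 4 `COC(=O)c1c[nH]nc1/N=N/N(C)C` has not been measured. It differs from compound 3 in one place: methoxy in place of amino on a carbonyl carbon. The place is the same, word for word, as in the change from compound 1 to compound 2, a carbonyl carbon whose other neighbour is an aromatic carbon, so this is the same change carried onto the core of compound 3.

Within the data shown here, for compound 4 the expected step in this assay is a number 0.39 log units lower from compound 3 to compound 4 (beyond the scatter), set beside the measured a number 0.38 log units lower from compound 1 to compound 2 (beyond the scatter); the expectation rests on that single step, because a number 0.38 log units lower from compound 1 to compound 2 (beyond the scatter) is the only guide, and it is widened because the core of compound 3 is not the core of compound 1. Compound 4 is thus estimated at 3.1, expected between 2.7 and 3.5.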

Compound 4, logarithm of the reciprocal of the active concentration, log(1/C): 3.49
The estimate for compound 4 lay 0.39 log units below the measured number, and the stated range covers the measured number.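

In this assay, carbamoyl to methoxycarbonyl on the core of compound 3 gives no change at the digits printed from compound 3 to compound 4 (within the scatter). Set beside the earlier instance of the same change, the two steps cannot be told apart: the same change on two cores in this assay, a number 0.38 log units lower (beyond the scatter) from compound 1 to compound 2 and no change at the digits printed (within the scatter) from compound 3 to compound 4, 0.38 log units apart, within the scatter of two such steps

Within the data shown here, this shows that the series offers no firm sign of the change behaving differently on the two cores, although only the step on the core of compound 1 lies beyond the scatter when read alone. It does not show that the change carries a fixed size from one core to the other, since a single pair on each core cannot separate a modest common step from a real dependence on the core, and the drop seen on the core of compound 1 therefore remains unconfirmed on the core of compound 3.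

The compounds shown leave open how other groups on the same carbonyl carbon would read on these two cores, for example a carboxylic acid, an ethyl ester or a dimethylamide. They also leave open whether a longer chain in place of the methyl groups on the triazene would alter the comparison between the cores.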